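This account rests on a few compounds, and the source may have more. Where it says the series, first, only, none or still open, it means among the compounds named here.

Measured so far:
compound 1, `CC(=O)NCC=C(c1ccccc1)c1ccccc1`, which in an assay on NIH3T3 cells for displacement of a labelled ligand from melatonin receptor type 1B (Homo sapiens) (a lower number here means a stronger inhibitor, a higher number a weaker inhibitor), gives 11.5 nM
compound 2, `O=C(NCC=C(c1ccccc1)c1ccccc1)C1CCC1`, which in this assay gives 13.2 nM

Going by the values given here, compound 2 holds the highest of the two numbers in this assay, but its only neighbour is compound 1, and the step of a 1.1-fold higher number from compound 1 to compound 2 (0.06 log units; within the scatter) is within the scatter, so the two compounds cannot be ordered. Compound 3, `COc1cccc(/C(=C\CNC(=O)C2CCC2)c2ccccc2)c1`, has not yet been measured in this assay. It differs from compound 2 by methoxy in place of hydrogen on an aromatic carbon. Among the compounds with values here, the single measured step, a 1.1-fold higher number from compound 1 to compound 2 (0.06 log units; within the scatter), concerns the group on the carbonyl carbon and says nothing about a substituent on one of the aromatic rings; no measured step bears on this change. The expectation therefore rests on compound 2 alone, and the direction of any shift is open. Compound 3 is expected to give about 8 nM, between 2 nM and 30 nM, which means an expected step of a 1.7-fold lower number from compound 2 to compound 3 (0.22 log units; within the scatter), not clearly beyond the scatter.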

Compound 3, inhibition constant: 1.55 nM
Compound 3: the middle estimate sits 5.2-fold (0.71 log units) above what was measured; measured number outside the range, below it.
By their numbers in this assay, from the lowest: compound 3; then compounds 1 and 2 (each within the scatter of the next).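

In this assay, methoxy in place of hydrogen on an aromatic carbon, meta to a large group, gives an 8.5-fold lower number from compound 2 to compound 3 (0.93 log units; beyond the scatter), so compound 3 is a stronger inhibitor than compound 2. Going by these compounds alone, the earlier change, at the group on the carbonyl carbon, gave only a 1.1-fold higher number from compound 1 to compound 2 (0.06 log units; within the scatter), which showed no readable shift; this aromatic position is the first place where a single change clearly moves the number. Nothing available explains why this substitution has that effect.

Going by these compounds, it remains open whether the gain is specific to methoxy or would also come with a hydroxy group, an ethoxy group or a chlorine atom at the same carbon, and whether methoxy would do the same on other carbons of that ring. On these data alone, it is also open whether the gain would carry over to the methyl amide, compound 1.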